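The source may report more compounds than this note shows. Statements on the series, on what has been measured and on what is new or still open speak of the compounds shown alone.

Of the compounds shown here, three of a shared core have been measured in an assay on isolated protein for inhibition of DNA topoisomerase 1 (Homo sapiens), with a stated time of 30 min, tested at 100 uM; a higher number here means a stronger effect of the compound at the concentration tested, a lower number a weaker effect. Compound 1, with the structure `Oc1ccc(-c2cc(-c3ccccc3)nc(-c3ccccc3Cl)c2)cc1`, gives 13.6% in this assay. Compound 2, with the structure `Oc1ccc(-c2cc(-c3ccc(Cl)cc3)nc(-c3ccsc3)c2)cc1`, gives 47.7%, which is the highest of the three numbers: compound 1 lies beyond the scatter below it, and compound 3, with the structure `Oc1cccc(-c2cc(-c3ccc(Cl)cc3)nc(-c3ccsc3)c2)c1`, gives 11.7% and is the furthest from it of the three. For the measured compounds named here, the single step between two measured compounds that differ in one place is the one in this assay of a number 36 percentage points lower from compound 2 to compound 3 (beyond the scatter), a large loss.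

Compound 4, with the structure `Oc1ccc(-c2cc(-c3ccccc3)nc(-c3ccc(Cl)cc3)c2)cc1`, has not yet been measured. It differs from compound 2 by phenyl in place of thiophen-3-yl on an aromatic carbon. Going by the values given here, no measured step covers this exchange: the one measured step concerns the hydroxyphenyl group instead, and compound 1 differs from compound 2 in more than one place, so its lower value shows only that other variation at these positions can cost much. On that basis compound 4 is expected to come in below compound 2, by a step of a number 12.7 percentage points lower from compound 2 to compound 4 (beyond the scatter). The estimate for compound 4 in this assay is therefore 35%, with a range from 10% to 60%.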

Compound 4, a percentage reported as inhibition, at one concentration (the size of the read-out at that concentration, not a potency): 68%
The estimate for compound 4 lay 33 percentage points below the measured number; the whole stated range lies below it.
By their numbers in this assay, from the lowest: compounds 3 and 1 (each within the scatter of the next); then compound 2; then compound 4.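

In this assay the aromatic carbon next to the ring nitrogen turns out to tolerate a change of ring, and the thiophen-3-yl group is not needed for the effect: phenyl in its place gives a number 20.3 percentage points higher from compound 2 to compound 4 (beyond the scatter) in a modest gain. The chlorophenyl group also matters, as 4-chlorophenyl in place of 2-chlorophenyl gives a number 54.4 percentage points higher from compound 1 to compound 4 (beyond the scatter) as a large gain. For the compounds shown here, this is the first measured step to show that the position of the chlorine on that ring can decide much of the read-out.

The compounds shown leave open whether an amine, a carboxylic acid or a methoxy group on this phenyl ring would keep or extend the gain. Nothing given here explains why either step goes as it does.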